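The compounds below may be only part of what the source reports. "The series", "measured", "known", "first", "only" and "open" are said of these compounds alone.

Measured so far:
- compound 1, `O=C(O)CCN1Cc2ccc(NC(=O)c3ccc(C4CCNCC4)cc3)cc2C1=O`, 9600 nM
- compound 2, `O=C(O)CN1Cc2ccc(NC(=O)c3ccc(C4CCNCC4)cc3)cc2C1=O`, 24000 nM
- compound 3, `O=C(O)CN1Cc2ccc(NC(=O)CC3CCNCC3)cc2C1=O`, 51000 nM

All three were tested in a functional assay on a cell-free system (Platelet, plasma, Homo sapiens) for inhibition; on this read-out lower numbers stand for stronger inhibition and higher numbers for weaker inhibition. Compound 1 and compound 2 share one core and differ in a single place: carboxymethyl in place of carboxy on a saturated chain carbon bound to an amide-type nitrogen in a ring. That change gave a 2.5-fold lower number from compound 2 to compound 1 (0.40 log units; beyond the scatter). Compound 3 carries a different core; how the core of compound 3 differs from the core of compound 2 is not broken down here. In this assay compound 3 gives the highest number of the three, and compound 2 comes nearest to it.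

Compound 4, `O=C(O)CCN1Cc2ccc(NC(=O)CC3CCNCC3)cc2C1=O`, has not yet been measured in this assay. It is reached from compound 3 by carboxymethyl in place of carboxy on a saturated chain carbon bound to an amide-type nitrogen in a ring. The place line is the same word for word as in the change from compound 2 to compound 1, so the two changes are the same, made on two different cores. Because compound 1 and compound 2 showed a 2.5-fold lower number from compound 2 to compound 1 (0.40 log units; beyond the scatter), the same step is expected from compound 3 to compound 4, roughly a 2.6-fold lower number from compound 3 to compound 4 (0.41 log units; beyond the scatter). Among the measured compounds shown here, this rests on one measured pair only, and on the assumption that the change acts alike on both cores, which no further compound here confirms. Compound 4 is therefore estimated at 20000 nM, with a likely span from 8000 nM to 50000 nM.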

Compound 4, half-maximal inhibitory concentration: 7400 nM
The estimate for compound 4 lay 2.7-fold (0.43 log units) above the measured number; measured number outside the range, below it.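

In this assay, the change from carboxymethyl to 2-carboxyethyl again lowered the number, giving a 6.9-fold lower number from compound 3 to compound 4 (0.84 log units; beyond the scatter), so its direction carried over from the first core to the second. Its size did not carry over, and the two steps stand clearly apart: the same change on two cores in this assay, a 2.5-fold lower number (0.40 log units; beyond the scatter) from compound 2 to compound 1 and a 6.9-fold lower number (0.84 log units; beyond the scatter) from compound 3 to compound 4, 2.8-fold (0.44 log units) apart, beyond the scatter of two such steps. The series therefore supports reading the direction of this change across these two cores, but not transferring its size, and with a single pair on each core it neither explains the gap nor shows how the change would behave on a third core.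

The compounds shown stop at the 2-carboxyethyl chain, so it remains open whether a longer chain, such as 3-carboxypropyl, would lower the number further or reverse the gain. On these data alone, it also remains open what an ester or a primary amide would do in place of the carboxylic acid, and so whether the acid itself is needed for the inhibition seen here.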